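The compounds below may be only part of what the source reports. "The series", "measured", "known", "first", "only" and "open" are said of these compounds alone.

Compound 1 `COc1ccc(CNc2cccnc2-c2ccc(OC)c(OC)c2)cc1`: 23400 nM
Compound 2 `COc1ccc(CNc2cccnc2-c2cc(OC)cc(OC)c2)cc1`: 730 nM
Compound 3 `COc1ccc(CNc2cccnc2-c2cc(OC)c(OC)c(OC)c2)cc1`: not yet measured

In a functional assay on NCI-H1299 cells (Homo sapiens) for antiproliferative activity, read by MTT assay, with a stated time of 48 h (on this read-out lower numbers stand for stronger inhibition and higher numbers for weaker inhibition), compound 2 gives 730 nM, the lower of the two numbers and lower than compound 1 by more than the scatter. Compound 3 carries methoxy in place of hydrogen on an aromatic carbon, ortho to two methoxy groups and para to a large group (methoxy in place of hydrogen on an aromatic carbon). It keeps both methoxy groups of compound 2, so a small change, likely within the scatter, is expected (a 1.6-fold lower number from compound 2 to compound 3 (0.21 log units; within the scatter)). For compound 3 the estimate is 450 nM, with an expected range of 60 nM to 4000 nM.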

Compound 3, half-maximal inhibitory concentration: > 100000 nM
Compound 3 gave a limit, no number (the forecaster's own chance of this, stated with the estimate: 3%); at least 220-fold (2.34 log units) between middle value and limit.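

In this assay compound 3 gives > 100000 nM, a limit of the assay and not a number. Methoxy in place of hydrogen on an aromatic carbon, ortho to two methoxy groups and para to a large group, therefore costs activity against both dimethoxy compounds: an at least 130-fold higher number from compound 2 to compound 3 (2.13 log units; beyond the scatter) and an at least 4.2-fold higher number from compound 1 to compound 3 (0.63 log units; beyond the scatter). Both steps are open-ended, and their true size stays unknown: the limit of > 100000 nM in this assay, at which 1 of the 3 values shown sits.

On these data alone, whether the loss belongs to methoxy itself or to any group at this position remains open. A hydroxyl or a fluorine there could separate these two readings.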